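A few compounds are considered here, and "the series" means these few. Any claim that something is new, unique, unknown or untested is made for them only; others in the source may bear on it.

In a toxicity assay on GES1 cells (Homo sapiens) for inhibition, read by MTT assay, with a stated time of 72 h (a higher number here means a weaker inhibitor, a lower number a stronger inhibitor), compound 1 `Cc1cc(N2CC[C@@H](C)[C@@H](N(C)c3ncnc4[nH]ccc34)C2)n2ncnc2n1` gives 57900 nM, compound 2 `Cc1cc(N2CC[C@@H](C)[C@@H](N(C)c3ncnc4[nH]ccc34)C2)n2nc(SCC3CCCCC3)nc2n1` gives 98200 nM and compound 3 `Cc1ccc(CSc2nc3nc(C)cc(N4CC[C@@H](C)[C@@H](N(C)c5ncnc6[nH]ccc56)C4)n3n2)cc1` gives 82500 nM, which places compound 3 within the scatter of both others. Compound 4 `C#CSc1nc2nc(C)cc(N3CC[C@@H](C)[C@@H](N(C)c4ncnc5[nH]ccc45)C3)n2n1` has not been measured. It differs from compound 3 by ethynyl in place of 4-methylbenzyl on a sulfur. The nearest evidence comes from the steps at that sulfur substituent: a 1.7-fold higher number from compound 1 to compound 2 (0.23 log units; within the scatter), a 1.4-fold higher number from compound 1 to compound 3 (0.15 log units; within the scatter) and a 1.2-fold lower number from compound 2 to compound 3 (0.08 log units; within the scatter). Going by the values given here, all three stay within the scatter, though no ethynyl compound has been measured. The expected result in this assay is therefore a 1.1-fold lower number from compound 3 to compound 4 (0.06 log units; within the scatter), no step beyond the scatter. The estimated value for compound 4 is 72000 nM, within an expected range of 35000 nM to 140000 nM.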

Compound 4, half-maximal inhibitory concentration: > 100000 nM
Compound 4 gave a limit, no number; the forecaster's own chance of this, stated with the estimate: 10%; middle value at least 1.3-fold (0.14 log units) away from the limit.
By their numbers in this assay, from the lowest: compounds 1, 3 and 2 (each within the scatter of the next). At a limit, above all of these: compound 4.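

In this assay compound 4 gives > 100000 nM, which is a limit and not a number: the limit of > 100000 nM in this assay, at which 1 of the 4 values shown sits. The steps to it are floors only: an at least 1.2-fold higher number from compound 3 to compound 4 (0.08 log units; that floor lies within the scatter), an at least 1.0-fold higher number from compound 2 to compound 4 (0.00 log units; that floor lies within the scatter) and an at least 1.7-fold higher number from compound 1 to compound 4 (0.23 log units; that floor lies within the scatter). Ethynyl is the first group shown on this sulfur that carries no ring, and this small group gives no sign of a stronger inhibitor than the ring-bearing 4-methylbenzyl or cyclohexylmethyl.

From the compounds shown here alone, how far compound 4 lies beyond its limit stays open. So does whether an amine or a carboxylic acid on this sulfur would give a clearly lower number.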